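A few compounds are considered here, and "the series" means these few. Any claim that something is new, unique, unknown or untested is made for them only; others in the source may bear on it.

Measured compounds:
Compound 1 `COc1ccccc1/C=C1\CCc2cc(OC)c(OC)cc2C1=O` gives in a functional assay on Jurkat cells (Homo sapiens) for antiproliferative activity, read by MTT assay (on this read-out higher numbers stand for weaker inhibition and lower numbers for stronger inhibition), a value of > 50000 nM, a limit of the assay.
Compound 2 `COc1ccc(/C=C2\CCc3cc(OC)c(OC)cc3C2=O)cc1` gives in this assay a value of > 50000 nM, likewise a limit.
Compound 3 `COc1cc2c(cc1OC)C(=O)/C(=C/c1ccc(N)cc1)CC2` gives in this assay a value of 40000 nM.

Among the compounds with values here, compound 3 thus stands as the only real number among the three; the other two sit at the limit of > 50000 nM in this assay, at which 2 of the 3 values shown sit. The step from compound 1 to compound 2 is a step that the two limits leave unreadable from compound 1 to compound 2. The steps that reach compound 3 are an at least 1.2-fold lower number from compound 1 to compound 3 (0.09 log units; that floor lies within the scatter) and an at least 1.2-fold lower number from compound 2 to compound 3 (0.09 log units; that floor lies within the scatter); neither floor rises above the scatter, so compound 3 cannot be called more potent than either.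

Compound 4 `COc1cc2c(cc1OC)C(=O)/C(=C/c1cc(C)ccc1C)CC2` carries the change (2,5-dimethylphenyl in place of 4-aminophenyl on a double-bonded chain carbon bound to a double-bonded ring carbon). The two measured steps onto compound 3 show only that an aminophenyl gives a readable number where two methoxyphenyls give limits, and a dimethylphenyl without donor or acceptor resembles neither case closely. In this assay he therefore expects no step beyond the scatter, with the number most likely near the limit again. Compound 4 is expected to give 45000 nM, within a range from 15000 nM to 150000 nM. For compound 4 this estimate implies a step of a 1.1-fold higher number from compound 3 to compound 4 (0.05 log units; within the scatter).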

Compound 4, half-maximal inhibitory concentration: 6000 nM
Beside the measured number, compound 4's estimate is 7.5-fold (0.88 log units) above it, outside the stated range (below it).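

In this assay, the group on a double-bonded chain carbon bound to a double-bonded ring carbon proves able to shift the number beyond the scatter, which the first three compounds could not show: the change to 2,5-dimethylphenyl gives a 6.7-fold lower number from compound 3 to compound 4 (0.82 log units; beyond the scatter). Measured against the two methoxyphenyl compounds, the same change gives an at least 8.3-fold lower number from compound 2 to compound 4 (0.92 log units; beyond the scatter) and an at least 8.3-fold lower number from compound 1 to compound 4 (0.92 log units; beyond the scatter); these sizes are only floors, because both starting values are limits of the assay and not numbers: the limit of > 50000 nM in this assay, at which 2 of the 4 values shown sit. Compound 4 is thus the most potent of the four, and its 2,5-dimethylphenyl, with 0 hydrogen-bond donors and 0 hydrogen-bond acceptors, shows that the amino group of compound 3 is not needed for a readable number here.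

As far as these compounds go, it remains open whether a single methyl, as in 2-methylphenyl or 3-methylphenyl, would suffice, or whether both methyl groups are needed for this step. From the compounds shown here alone, it is equally open whether a 2,5-dichlorophenyl or a 2,5-dimethoxyphenyl would match compound 4 or fall back to the limit.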